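The source may hold more compounds than are shown below. What is called first, only, known or untested is meant among the compounds shown, and "the series" means these compounds.

Series notes. Among the compounds with values here, in an assay on microsomes from liver for inhibition of acyl-CoA desaturase 1 (Rattus norvegicus) (a higher number here means a weaker inhibitor, a lower number a stronger inhibitor), compound 1 `Brc1ccccc1OC1CCN(c2ccc(-n3ccnc3)nn2)CC1` gives 5 nM, second highest of the three numbers so far, with compound 3 `Oc1nnc(-c2ccc(N3CCC(Oc4ccccc4C(F)(F)F)CC3)nn2)s1` at 6.1 nM nearest and compound 2 `OCc1nnc(-c2ccc(N3CCC(Oc4ccccc4C(F)(F)F)CC3)nn2)s1` at 3.2 nM furthest, both within the scatter of it. Within the data shown here, the only measured step, a 1.9-fold higher number from compound 2 to compound 3 (0.28 log units; within the scatter), concerns a different part of the shared core and stayed within the scatter. Compound 4 `CCc1cccc(OC2CCN(c3ccc(-n4ccnc4)nn3)CC2)c1` differs from compound 1 by 3-ethylphenyl in place of 2-bromophenyl on an oxygen on a saturated carbon. Among the measured compounds shown here, no measured step bears on an exchange of this aryl group, so nothing in the data argues for a shift beyond the scatter, and the range is kept wide. Compound 4 is therefore expected at 8 nM, between 2.5 nM and 25 nM, an expected step of a 1.6-fold higher number from compound 1 to compound 4 (0.20 log units; within the scatter).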

Compound 4, half-maximal inhibitory concentration: 38 nM
The estimate for compound 4 lay 4.8-fold (0.68 log units) below the measured number; measured number outside the range, above it.
By their numbers in this assay, from the lowest: compounds 2, 1 and 3 (each within the scatter of the next); then compound 4.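

In this assay, within the data shown here, the aryl group on an oxygen on a saturated carbon is the first place where a single exchange goes beyond the scatter: 3-ethylphenyl in place of 2-bromophenyl gives a 7.6-fold higher number from compound 1 to compound 4 (0.88 log units; beyond the scatter) in a modest step. Among these compounds, the number therefore responds to this exchange, whereas the only earlier step, on a different part of the core, stayed within the scatter. No measurement shown accounts for the step. As far as these compounds go, whether it follows from the ethyl, the loss of bromine or the changed ring position stays open; 3-bromophenyl and 2-ethylphenyl would separate these. From the compounds shown here alone, how a carboxylic acid or an amine on this phenyl ring would read is also open.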